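Dichloroacetanilides: a second ring chlorine added to compound 2

This account rests on a few compounds, and the source may have more. Where it says the series, first, only, none or still open, it means among the compounds named here.

Working notes on a small set of dichloroacetanilides. Compound 1 `O=C(Nc1ccccc1Cl)C(Cl)Cl`, compound 2 `O=C(Nc1cccc(Cl)c1)C(Cl)Cl` and compound 3 `O=C(Nc1cccc(NC(=O)C(Cl)Cl)c1)C(Cl)Cl` share the dichloroacetamide core and differ only in what sits on the aromatic ring. In a functional assay on Bel-7402 cells (Homo sapiens) for antiproliferative activity, read by MTT assay, with a stated time of 72 h (on this read-out higher numbers stand for weaker inhibition and lower numbers for stronger inhibition), compound 2 gives 44500 nM. Going by the values given here, this is the only number in the set: in this assay compound 1 gives "not determined" (no result reported) and compound 3 gives "not determined" (no result reported), so nothing can be said about how the placement of the chloro group or the second amide moves the read-out, and compound 2 stands alone as the single reference point.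

Compound 4 `O=C(Nc1cccc(Cl)c1Cl)C(Cl)Cl` remains to be measured in this assay. Relative to compound 2 the change is chloro in place of hydrogen on an aromatic carbon. Among the compounds with values here, no step between two measured compounds is available to gauge a change of this kind, so the expectation rests on compound 2 alone. A single added chlorine is expected to shift the half-maximal inhibitory concentration only modestly, and the estimated step of a 1.5-fold lower number from compound 2 to compound 4 (0.17 log units; within the scatter) is not expected to lie clearly beyond the scatter in either direction. For compound 4 in this assay the estimate is 30000 nM, with a range from 10000 nM to 100000 nM. Given the weak figure of compound 2, some chance remains that compound 4 returns only a limit rather than a number.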

Compound 4, half-maximal inhibitory concentration: 180000 nM
The estimate for compound 4 lay 6.0-fold (0.78 log units) below the measured number, and the stated range ends below it.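

In this assay the chloro group entering on the aromatic carbon ortho to a chloro group and ortho to a group of 6 heavy atoms gives a 4.0-fold higher number from compound 2 to compound 4 (0.61 log units; beyond the scatter) and so moves the read-out toward weaker inhibition. Going by these compounds alone, this is the first step between two measured compounds, and it shows that this carbon is not indifferent to substitution, since replacing hydrogen with a single chlorine here changes the read-out beyond the scatter. Nothing available explains why the added chlorine has this effect.

Within the data shown here, the single step does not separate the contribution of this position from that of chloro as the entering group, so it remains open whether a fluorine atom, a methyl group, an amine or a carboxylic acid on the same carbon would move the read-out in the same direction. On these data alone, it also remains open whether chloro on this carbon would have the same effect without the chloro group already present in compound 2.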